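Shortening the chain oxygen substituent of compound 2 to methyl

The source may hold more compounds than are shown below. What is called first, only, known or untested is meant among the compounds shown, and "the series" means these compounds.

Measured compounds in a functional assay on K562 cells (Homo sapiens) for cytotoxicity, read by MTT assay, with a stated time of 72 h; on this read-out higher numbers stand for weaker inhibition and lower numbers for stronger inhibition:
- compound 1 `[O-][n+]1nc(NCOCc2ccc(Cl)cc2)[n+]([O-])c2ccccc21` gives 1850 nM
- compound 2 `COc1ccc(COCNc2n[n+]([O-])c3ccccc3[n+]2[O-])cc1` gives 660 nM
- compound 3 `CCCOCNc1n[n+]([O-])c2ccccc2[n+]1[O-]` gives 3890 nM

Of these three, compound 2 has the lowest number, so it is the strongest inhibitor in this set: its nearest neighbour is compound 1, with a 2.8-fold lower number from compound 1 to compound 2 (0.45 log units; beyond the scatter), and compound 3 lies furthest away, with a 5.9-fold higher number from compound 2 to compound 3 (0.77 log units; beyond the scatter).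

Compound 4 `CCOCNc1n[n+]([O-])c2ccccc2[n+]1[O-]` has not yet been measured. It differs from compound 2 in one place: methyl in place of 4-methoxyphenyl on a saturated chain carbon bound to an oxygen on a saturated carbon

For the measured compounds named here, the step that bears most directly on this change is the one from compound 2 to compound 3, where ethyl replaced 4-methoxyphenyl at the same place and the number rose, a 5.9-fold higher number from compound 2 to compound 3 (0.77 log units; beyond the scatter). The step from compound 1 to compound 3, where ethyl replaced 4-chlorophenyl, also went up, a 2.1-fold higher number from compound 1 to compound 3 (0.32 log units; beyond the scatter). Both show that removing the aromatic ring from the chain raises the number. Compound 4 carries an even shorter group than compound 3, so in this assay a rise at least as large as that seen for compound 3 is expected.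

Compound 4 is therefore estimated at 5000 nM, in a range from 2000 nM to 15000 nM, which means an expected step of a 7.6-fold higher number from compound 2 to compound 4 (0.88 log units; beyond the scatter).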

Compound 4, half-maximal inhibitory concentration: 4990 nM
For compound 4 the middle estimate is 1.0-fold (0.00 log units) above the measured one, within the range that was stated.
By their numbers in this assay, from the lowest: compound 2; then compound 1; then compounds 3 and 4 (each within the scatter of the next).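

In this assay, replacing the 4-methoxyphenyl with methyl at this place on the chain gives a clear rise (a 7.6-fold higher number from compound 2 to compound 4 (0.88 log units; beyond the scatter)), and replacing the 4-chlorophenyl with methyl gives a smaller one (a 2.7-fold higher number from compound 1 to compound 4 (0.43 log units; beyond the scatter)), so the link between the aromatic ring and a lower number now holds for a second small chain. The new information lies in the comparison of the two chains without a ring: the step that trims the chain by one carbon (a 1.3-fold higher number from compound 3 to compound 4 (0.11 log units; within the scatter)) cannot be told apart from the usual scatter, so among these compounds, the length of the short chain makes no readable difference once the ring has gone. No measurement shown here explains why the aromatic ring goes with the lower numbers at this place.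

The compounds shown leave open whether a saturated cyclohexyl ring in this place would give numbers like those of compound 1 and compound 2, or whether the ring must be aromatic. They also leave open how a longer chain such as hexyl, or a chain ending in an amine, would read in this assay.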